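A few compounds are considered here, and "the series" means these few. Any claim that something is new, unique, unknown or untested is made for them only; others in the source may bear on it.

Three esters sharing one core have been measured. Compound 1 `O=C(CCCCC1CCCCC1)OCC1COCCOCCOCCOCCOCCO1` carries a cyclohexyl group on its saturated chain; compound 2 `O=C(OCC1COCCOCCOCCOCCOCCO1)c1cccc(-c2ccc(Br)cc2)c1` and compound 3 `O=C(CCCCCCCCCCOc1ccccc1)OCC1COCCOCCOCCOCCOCCO1` are the other two. In a functional assay on WiDr cells (Homo sapiens) for inhibition, read by sulforhodamine B assay, with a stated time of 48 h (on this read-out higher numbers stand for weaker inhibition of growth and lower numbers for stronger inhibition of growth), compound 1 gives 33000 nM, the second highest of the three numbers. Compound 3 gives 66000 nM, which lies within the scatter of the number for compound 1, whereas compound 2 gives 6200 nM, a lower number beyond the scatter. Compound 4 `O=C(CCCCc1ccccc1)OCC1COCCOCCOCCOCCOCCO1` differs from compound 1 in one place: phenyl in place of cyclohexyl on a saturated chain carbon, four bonds along the chain from a carbonyl carbon. Within the data shown here, no measured pair shows this exchange, so its size here is unknown. Compound 4 is expected to give about 25000 nM, within a range from 8000 nM to 80000 nM. The expected step of a 1.3-fold lower number from compound 1 to compound 4 (0.12 log units; within the scatter) stays within the scatter, leaning toward stronger inhibition.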

Compound 4, concentration for 50% growth inhibition: > 100000 nM
Compound 4: no number, only a limit; the forecaster's own chance of this, stated with the estimate: 5%; middle value at least 4.0-fold (0.60 log units) from the limit.
By their numbers in this assay, from the lowest: compound 2; then compounds 1 and 3 (each within the scatter of the next). At a limit, above all of these: compound 4.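

In this assay, the step from the saturated ring to the flat aromatic ring of the same size is an at least 3.0-fold higher number from compound 1 to compound 4 (0.48 log units; beyond the scatter), so this place on the chain does not treat the two rings alike, although they have the same count of heavy atoms. Compound 4 gives a limit, not a number: the limit of > 100000 nM in this assay, at which 1 of the 4 values shown sits.

From the compounds shown here alone, how an amine or a carboxylic acid on the ring would read here stays open. So does whether a longer chain carrying the phenyl group would bring the growth inhibition back.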